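The source may hold more compounds than are shown below. What is called first, only, known or untested is meant among the compounds shown, and "the series" means these compounds.

In an ADME assay for permeability, using PAMPA (on this read-out higher numbers stand for higher permeability and lower numbers for lower permeability), three relatives on a shared core set the scene, and only one of them carries a number. Compound 2 `COc1ccc(Cl)c(-c2noc(C(C)C)c2COc2ccc(-c3ccc4c(C(=O)O)cn(C)c4c3)c(C)c2)n1` reads 0.7 10^-6 cm/s. Compound 1 `Cc1cc(OCc2c(-c3cc[nH]c(=O)c3Cl)noc2C(C)C)ccc1-c1ccc2c(C(=O)O)cn(C)c2c1` is reported as "not active" (no number reported), with no figure attached. Compound 3 `Cc1cc(OCc2c(-c3c(Cl)cn(C)c(=O)c3Cl)noc2C(C)C)ccc1-c1ccc2c(C(=O)O)cn(C)c2c1` is in the same position: its entry reads "not active" (no number reported), so it has no single number, and compound 1 is the one further entry of that kind.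

Compound 4 `Cc1cc(OCc2c(-c3ccn(C)c(=O)c3Cl)noc2C(C)C)ccc1-c1ccc2c(C(=O)O)cn(C)c2c1` has not yet been measured in this assay. The step that leads to it is hydrogen in place of chloro on an aromatic carbon, ortho to a large group and two atoms from the ring nitrogen. The rest of the structure stays the same.

Compound 3 offers no figure to count a step from, so the size of this step cannot be read from the data. No step beyond the usual scatter is expected from this swap, and no direction can be favoured. For the measured compounds named here, the one numeric anchor is compound 2 at 0.7 10^-6 cm/s, and a low reading is expected, with a report without a number remaining quite possible. For compound 4 the estimated value is 0.4 10^-6 cm/s, with an expected range from 0.1 10^-6 cm/s to 1.2 10^-6 cm/s.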

Compound 4, apparent permeability: "not active" (no number reported)
The entry for compound 4 holds no number; no gap can be computed for the estimate.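

In this assay compound 3 and compound 4 both stand without a number, so no step can be read between them. No measured evidence bears on this result. The compounds shown leave open whether hydrogen in place of chloro shifts the read-out at all, and in which direction.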